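A Carboxyphenyl Amide Replaces a Dimethylamide

A few compounds are considered here, and "the series" means these few. Any claim that something is new, unique, unknown or untested is made for them only; others in the source may bear on it.

Three measured compounds share one core. Compound 1 `COC(=O)c1ccc(NC(=O)[C@H]2CC=C(CCC=C(C)C)C[C@@H]2c2ccccc2)cc1` carries a methoxycarbonyl group on the aromatic ring of its amide. In an assay on isolated protein for inhibition of Apoptosis regulator Bcl-2 (Homo sapiens), read by fluorescence polarization, with stated times of 5 min and 10 min (a lower number here means a stronger inhibitor, a higher number a weaker inhibitor), compound 1 gives > 23000 nM, which is a limit of the assay rather than a number. Compound 2 `CC(C)=CCCC1=CC[C@H](C(=O)Nc2ccc(O)cc2)[C@@H](c2ccccc2)C1` has hydroxy in place of methoxycarbonyl on an aromatic carbon. In this assay compound 2 gives > 23000 nM, again a limit. Compound 3 `CC(C)=CCCC1=CC[C@H](C(=O)N(C)C)[C@@H](c2ccccc2)C1` has dimethylamino in place of (4-hydroxyphenyl)amino on a carbonyl carbon. In this assay compound 3 gives > 23000 nM, also a limit. The steps a step that the two limits leave unreadable from compound 1 to compound 2 and a step that the two limits leave unreadable from compound 2 to compound 3 therefore cannot be sized, and all three values share (the limit of > 23000 nM in this assay, at which 3 of the 3 values shown sit).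

Compound 4 `CC(C)=CCCC1=CC[C@H](C(=O)Nc2ccc(C(=O)O)cc2)[C@@H](c2ccccc2)C1` differs from compound 3 by (4-carboxyphenyl)amino in place of dimethylamino on a carbonyl carbon. Since no measured step can be read, the data give no direction for this change in this assay. The estimated step that the limit leaves unreadable from compound 3 to compound 4 is expected to leave compound 4 at or near the same limit. Compound 4 is expected to give 30000 nM, within 8000 nM and 120000 nM.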

Compound 4, inhibition constant: > 23000 nM
Compound 4 ended at the assay's limit; the forecaster's own chance of this, stated with the estimate: 75%; the middle value lies beyond the limit too.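

In this assay compound 4 gives > 23000 nM, which is a limit and not a number. Its steps from compound 1, compound 2 and compound 3 therefore cannot be read: the limit of > 23000 nM in this assay, at which 4 of the 4 values shown sit. The compounds shown leave open how strong each of the four really is and whether any of these amide changes matters.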